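Methoxy step on the aryl ketone of the imide series

The compounds below may be only part of what the source reports. "The series", "measured", "known", "first", "only" and "open" are said of these compounds alone.

Measured so far in an assay on cells (1-87 tumor cell line) for inhibition of Polyunsaturated fatty acid 5-lipoxygenase (Homo sapiens), with a stated time of 5 min; a lower number here means a stronger inhibitor, a higher number a weaker inhibitor:
compound 1 , `NS(=O)(=O)c1ccc(N2C(=O)CC(C3CCCCC3=O)C2=O)cc1`, gives 21300 nM.
compound 2 , `O=C1CCCCCC1C1CC(=O)N(c2ccccc2)C1=O`, gives 18400 nM.
compound 3 , `NS(=O)(=O)c1ccc(N2C(=O)CC(CC(=O)c3ccccc3)C2=O)cc1`, gives 5290 nM.

Compound 3 stands lowest of the three numbers in this assay. Compound 2 comes nearest, with a higher number, and compound 1 is furthest; both gaps lie beyond the scatter, so compound 3 is the strongest inhibitor of the three. The values of compound 1 and compound 2 are close to each other, and no more is said of that pair.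

Compound 4 , `COc1ccc(C(=O)CC2CC(=O)N(c3ccc(S(N)(=O)=O)cc3)C2=O)cc1`, is not yet measured. Against compound 3 the change is methoxy in place of hydrogen on an aromatic carbon. Going by the values given here, no two measured compounds differ in this one place, so there is no measured step to lean on; the shared core and the aryl sulfonamide are untouched, and only the aryl ketone carries the new group. With nothing to show otherwise, a step of no more than the usual scatter is expected, in either direction, the number for compound 4 staying close to that of compound 3. The expected step is a 1.2-fold lower number from compound 3 to compound 4 (0.07 log units; within the scatter). Compound 4 is expected to give 4500 nM, with a range from 1500 nM to 14000 nM.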

Compound 4, half-maximal inhibitory concentration: 4740 nM
The estimate for compound 4 lay 1.1-fold (0.02 log units) below the measured number; measured number inside the range.
By their numbers in this assay, from the lowest: compounds 4 and 3 (each within the scatter of the next); then compounds 2 and 1 (each within the scatter of the next).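

Going by these compounds alone, this is the first measured step at this place, the aromatic carbon para to a large group on the six-membered aromatic ring of the aryl ketone. In this assay the exchange of phenyl for 4-methoxyphenyl gives a 1.1-fold lower number from compound 3 to compound 4 (0.05 log units; within the scatter), so the two compounds cannot be told apart and this place accepts a methoxy group, with its 2 heavy atoms and 1 hydrogen-bond acceptor, without a readable change in the number. No independent data are available to account for this outcome.

With a single substituent at a single place, the compounds shown say nothing yet on whether this insensitivity holds for other groups here, such as an amine, a carboxylic acid, a halogen or a longer alkoxy chain. Also open, going by these compounds, is whether a methoxy group on another carbon of this ring reads the same, and whether the same step holds when the aryl sulfonamide of compound 3 and compound 4 is replaced by the unsubstituted phenyl of compound 2.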